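This account rests on a few compounds, and the source may have more. Where it says the series, first, only, none or still open, it means among the compounds named here.

Three compounds have so far been measured in an assay on isolated protein for displacement of a labelled ligand from metabotropic glutamate receptor 5 (Homo sapiens), with a stated time of 60 min, tested at 1 uM; a higher number here means more inhibition at the concentration tested (going by the name of the read-out), a lower number less inhibition:

compound 1 `CC1CCN(c2c(S(=O)(=O)c3ccc(F)c(Cl)c3)cnc3cc(Cl)ccc23)CC1`, 94%
compound 2 `COc1ccc(S(=O)(=O)c2cnc3cc(Cl)ccc3c2N2CCC(C)CC2)cc1Cl`, 93%
compound 3 `CC1CCN(c2c(S(=O)(=O)c3cccc(Cl)c3)cnc3cc(Cl)ccc23)CC1`, 92%

Compound 3 stands lowest of the three numbers, yet the steps of a number 1 percentage points lower from compound 2 to compound 3 (within the scatter) and a number 2 percentage points lower from compound 1 to compound 3 (within the scatter) both lie within the scatter, so the three compounds cannot be ordered on these numbers. All three share one core, and all three differ from one another only in the substitution of the aryl group on the sulfonyl sulfur; the step of a number 1 percentage points lower from compound 1 to compound 2 (within the scatter) is likewise within the scatter.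

Compound 4 `CC1CCN(c2c(S(=O)(=O)c3ccc(C#N)cc3)cnc3cc(Cl)ccc23)CC1` is the next compound, and it differs from compound 3 in one place: 4-cyanophenyl in place of 3-chlorophenyl on a sulfonyl sulfur. Every measured step bears on this change, since each of them also swaps one substituent for another on that same aryl group, and each of them stayed within the scatter. The change to compound 4 is larger than any of those, as it replaces a chlorine with a nitrile and moves the substituent to another carbon of the ring, so a somewhat wider range is warranted. Still, on the evidence of the three measured steps, no step beyond the scatter is expected in this assay; the expected step is a number 5 percentage points lower from compound 3 to compound 4 (within the scatter). Compound 4 is therefore estimated to give 87%, in a range from 68% to 97%.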

Compound 4, a percentage reported as inhibition, at one concentration (the size of the read-out at that concentration, not a potency): 70%
Beside the measured number, compound 4's estimate is 17 percentage points above it; the measured number falls inside the stated range.
By their numbers in this assay, from the lowest: compound 4; then compounds 3, 2 and 1 (each within the scatter of the next).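

The aryl group on the sulfonyl sulfur, where every earlier swap stayed within the scatter in this assay, is not indifferent to all changes: 4-cyanophenyl in place of 3-chlorophenyl brings a number 22 percentage points lower from compound 3 to compound 4 (beyond the scatter), and the same group brings a number 23 percentage points lower from compound 2 to compound 4 (beyond the scatter) and a number 24 percentage points lower from compound 1 to compound 4 (beyond the scatter) against the other two aryl groups. Going by these compounds alone, the three earlier compounds all keep a chlorine on this ring and differ only in fluoro, methoxy or hydrogen, whereas compound 4 has no chlorine and carries a nitrile, and only the steps to compound 4 lie beyond the scatter. Nothing available explains why the number falls with this change.

On these data alone, whether the fall follows from the nitrile entering, from the chlorine leaving or from the substituent sitting on another carbon of the ring stays open, for this one change alters all three together. Also open, as far as these compounds go, is how this assay would read with an amine, a carboxylic acid or a longer alkyl chain on the aryl group, and whether any such group would keep the number of the chlorine-bearing compounds.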